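A few compounds are considered here, and "the series" means these few. Any claim that something is new, unique, unknown or untested is made for them only; others in the source may bear on it.

Compound 1 `O=c1c(Cc2coc3cccc(OCC4CCCCC4)c3c2=O)coc2cc(O)ccc12` is the reference point of this account. In a functional assay on NCI-H23 cells (Homo sapiens) for antiproliferative activity, read by XTT assay (on this read-out lower numbers stand for stronger inhibition and higher numbers for weaker inhibition), compound 1 gives 2150 nM, the lowest of the two numbers recorded. Its nearest neighbour is compound 2 `O=C1c2c(OCC3CCCCC3)cccc2OCC1Cc1coc2ccccc2c1=O`, which in this assay gives 9490 nM, a gap above compound 1 that lies beyond the usual scatter. Compound 3 `O=c1c(/C=C/c2coc3ccccc3c2=O)coc2ccccc12` yields no number in this assay but only a limit, > 10000 nM, and one of the three values shown sits at that limit (the limit of > 10000 nM in this assay, at which 1 of the 3 values shown sits).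

The next compound, compound 4 `O=c1c(Cc2coc3cccc(OCC4CCCCC4)c3c2=O)coc2cc(Cl)ccc12`, differs from compound 1 in a single place: chloro in place of hydroxy on an aromatic carbon. Among the compounds with values here, no pair of measured compounds differs by this change alone, so nothing recorded here reports what it does. Compound 1 carries the only hydroxy among the measured compounds and also holds the lowest number, which leaves the step open in both directions.

The step of a 1.9-fold higher number from compound 1 to compound 4 (0.27 log units; within the scatter) is expected to be a modest weakening, somewhat beyond the scatter. Compound 4 is therefore estimated to give 4000 nM in this assay, with a likely range from 1300 nM to 10000 nM.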

Compound 4, half-maximal inhibitory concentration: > 10000 nM
Compound 4 ended at the assay's limit; the forecaster's own chance of this, stated with the estimate: 25%; middle value at least 2.5-fold (0.39 log units) from the limit.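

Within the data shown here, this is the first step that can be read at all, and it concerns the aromatic carbon that is meta to a fused ring and para to a fused ring: in this assay, chloro in place of hydroxy gives an at least 4.6-fold higher number from compound 1 to compound 4 (0.66 log units; beyond the scatter). The earlier compounds shown here offered no pair differing in one place, so they left open which way this change would go, whereas the hydroxy of compound 1 can now be said to outperform chloro at this position in this cell read-out. The true size of the step remains open upward, since compound 4 stands at a limit of the assay and not at a number: the limit of > 10000 nM in this assay, at which 2 of the 4 values shown sit.

With a single replacement at this position, the compounds shown cannot say whether the hydroxy itself is needed or whether another group, such as a methoxy, an amine or a fluoro, would serve as well. They also leave open whether the same exchange would have a similar effect on a different core, such as that of compound 2.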